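From isopropoxy to 3,4-difluorophenyl on the shared core

The source may report more compounds than this note shows. Statements on the series, on what has been measured and on what is new or still open speak of the compounds shown alone.

Measured in a functional assay on the whole organism for inhibition, with Mus musculus as the target, with a stated time of 60 min; on this read-out lower numbers stand for an effect already at smaller amounts and higher numbers for an effect only at larger amounts of compound:
Compound 1 `C[C@H](Oc1ccc(S(C)(=O)=O)cc1C(=O)N1Cc2ccc(C(F)(F)F)cc2C1)C(F)(F)F`: 2 mg/kg
Compound 2 `C[C@H](Oc1ccc(S(C)(=O)=O)cc1C(=O)N1Cc2cc(C(F)(F)F)cnc2C1)C(F)(F)F`: 0.4 mg/kg
Compound 3 `CC(C)Oc1ccc(S(C)(=O)=O)cc1C(=O)N1Cc2cc(C(F)(F)F)cnc2C1`: 1 mg/kg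

The value of compound 3 lies within the scatter of that of compound 1. For the measured compounds named here, the one measured step that reaches it is a 2.5-fold higher number from compound 2 to compound 3 (0.40 log units; beyond the scatter), modest in size. Compound 4 `CS(=O)(=O)c1ccc(-c2ccc(F)c(F)c2)c(C(=O)N2Cc3cc(C(F)(F)F)cnc3C2)c1` carries 3,4-difluorophenyl in place of isopropoxy on an aromatic carbon. Going by the values given here, the measured step only exchanges one group on the oxygen for another, and no measured step replaces that oxygen-linked group with an aromatic ring. So in this assay no step beyond the scatter is expected, though with wide uncertainty in both directions. The estimated change is a 1.5-fold higher number from compound 3 to compound 4 (0.18 log units; within the scatter). The estimate for compound 4 is 1.5 mg/kg, with an expected range of 0.4 mg/kg to 6 mg/kg.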

Compound 4, dose for 50% inhibition: 1 mg/kg
Beside the measured number, compound 4's estimate is 1.5-fold (0.18 log units) above it; the range from low to high includes it.
By their numbers in this assay, from the lowest: compound 2; then compounds 3, 4 and 1 (each within the scatter of the next).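

In this assay the aromatic carbon para to a methylsulfonyl group accepts a directly attached ring in place of an oxygen-linked group, with no change at the digits printed from compound 3 to compound 4 (within the scatter) when 3,4-difluorophenyl replaces isopropoxy. The same ring set against 1-(trifluoromethyl)ethoxy gives a 2.5-fold higher number from compound 2 to compound 4 (0.40 log units; beyond the scatter) and so does not match that group. Nothing available bears on why either step came out this way. As far as these compounds go, it remains open whether the two fluorines matter, as an unsubstituted phenyl would show, and whether an amine such as morpholine would serve equally on this carbon.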